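The compounds below may be only part of what the source reports. "The series", "measured", "known", "first", "only" and "open" are said of these compounds alone.

Measured in a functional assay on HL-60 cells (Homo sapiens) for antiproliferative activity, read by MTT assay, with a stated time of 48 h; on this read-out lower numbers stand for stronger inhibition and higher numbers for weaker inhibition
- compound 1 `CC(=O)OC/C1=C/C[C@](C)(CCC=C(C)C)/C=C/[C@@H](OC(=O)C=C(C)C)[C@](C)(O)/C=C/C1=O` 2950 nM
- compound 2 `CC(C)=CCC[C@]1(C)/C=C/[C@@H](OC(=O)C=C(C)C)[C@](C)(O)/C=C/C(=O)/C(CN2CCN(C)CC2)=C\C1` 840 nM
- compound 3 `CC(C)=CCC[C@]1(C)/C=C/[C@@H](OC(=O)C=C(C)C)[C@](C)(O)/C=C/C(=O)/C(Cn2cc(CO)nn2)=C\C1` 3200 nM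

Compound 3 lies within the scatter of the acetoxy member (a 1.1-fold higher number from compound 1 to compound 3 (0.04 log units; within the scatter)) and clearly above the 4-methylpiperazin-1-yl member (a 3.8-fold higher number from compound 2 to compound 3 (0.58 log units; beyond the scatter)). Compound 4 `CC(C)=CCC[C@]1(C)/C=C/[C@@H](OC(=O)C=C(C)C)[C@](C)(O)/C=C/C(=O)/C(C(=O)N(C)C)=C\C1` follows from compound 3 by this change: dimethylcarbamoyl in place of (4-(hydroxymethyl)-1H-1,2,3-triazol-1-yl)methyl on a double-bonded ring carbon. Among the compounds with values here, no measured step tests dimethylcarbamoyl on this ring carbon. The nearest evidence is indirect. Replacing acetoxy gave a modest change only with 4-methylpiperazin-1-yl (a 3.5-fold lower number from compound 1 to compound 2 (0.55 log units; beyond the scatter)), and compound 4 lacks that group. No shift beyond the scatter is therefore expected, with an estimated 1.1-fold higher number from compound 3 to compound 4 (0.04 log units; within the scatter). For compound 4 the estimate is 3500 nM, with an expected range of 1300 nM to 9000 nM.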

Compound 4, half-maximal inhibitory concentration: 3340 nM
Estimate against measurement, compound 4: 1.0-fold (0.02 log units) above; the range from low to high includes it.
By their numbers in this assay, from the lowest: compound 2; then compounds 1, 3 and 4 (each within the scatter of the next).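

In this assay, dimethylcarbamoyl, a group with no ring, on this double-bonded ring carbon reads the same as the triazole-bearing side chain (a 1.0-fold higher number from compound 3 to compound 4 (0.02 log units; within the scatter)) and the acetoxymethyl group (a 1.1-fold higher number from compound 1 to compound 4 (0.05 log units; within the scatter)). The (4-methylpiperazin-1-yl)methyl group alone now stands apart, with a clear gap to the new amide (a 4.0-fold higher number from compound 2 to compound 4 (0.60 log units; beyond the scatter)). No available evidence bears on this result.

Still open, as far as these compounds go, is whether another amine on a saturated chain carbon here, such as morpholin-4-ylmethyl or dimethylaminomethyl, reads like compound 2. A carboxylic acid directly on this ring carbon is also untested in the compounds shown.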